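Chloro for hydrogen, repeated on a second core

The source may hold more compounds than are shown below. What is called first, only, known or untested is meant among the compounds shown, and "the series" means these compounds.

Compound 1 `ClCc1cccc(Cn2cnc3c(Cl)ncnc32)c1` and compound 2 `ClCc1cccc(Cn2cnc3c(Cl)nc(Cl)nc32)c1` share one core; compound 3 `ClCc1ccccc1Cn1cnc2ncnc(Cl)c21` and the unmeasured compound 4 `ClCc1ccccc1Cn1cnc2nc(Cl)nc(Cl)c21` share another. The difference between the two cores is not broken down here. In a functional assay on MDA-MB-231 cells (Homo sapiens) for cytotoxicity, read by sulforhodamine B assay, with a stated time of 48 h (a lower number here means a stronger inhibitor of growth, a higher number a weaker inhibitor of growth), compound 1 gives 4070 nM and compound 2 gives 3710 nM. The change between them, (chloro in place of hydrogen on an aromatic carbon), made a step of a 1.1-fold lower number from compound 1 to compound 2 (0.04 log units; within the scatter). In this assay compound 3 gives 6910 nM; set against compound 1 and compound 2 this lies within the scatter, so no order among the three is read from it. Compound 4 carries the same change on its own core, (chloro in place of hydrogen on an aromatic carbon), at a place described in identical terms. Since a 1.1-fold lower number from compound 1 to compound 2 (0.04 log units; within the scatter) stayed within the scatter, compound 4 is expected to move by about the same small amount in this assay, a 1.1-fold lower number from compound 3 to compound 4 (0.04 log units; within the scatter). The estimate for compound 4 is 6300 nM, with 3500 nM to 11500 nM as the expected range. This rests on a single measured pair; nothing else in the set tests the change.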

Compound 4, concentration for total growth inhibition: 910 nM
Compound 4: middle estimate off by 6.9-fold (0.84 log units), on the high side, outside the stated range (below it).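

In this assay, chloro in place of hydrogen on an aromatic carbon gave a 7.6-fold lower number from compound 3 to compound 4 (0.88 log units; beyond the scatter), so the change did not carry over at one size from the core of compound 1 to the core of compound 3: the same change on two cores in this assay, a 1.1-fold lower number (0.04 log units; within the scatter) from compound 1 to compound 2 and a 7.6-fold lower number (0.88 log units; beyond the scatter) from compound 3 to compound 4, 6.9-fold (0.84 log units) apart, beyond the scatter of two such steps Within these two pairs, the size of the step therefore depends on the core that carries it, and a result from one core gives no safe estimate for the other. The data do not show which part of the difference between the two cores sets this gap, nor do two pairs give a rule for any third core.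

Going by these compounds, it remains open whether an amine or a methoxy group, placed on the same aromatic carbon between two ring nitrogen atoms, would match the chloro group of compound 4 on this core. On these data alone, it is also open whether the large step would survive with a hydroxymethyl group in place of the chloromethyl group.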